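A few compounds are considered here, and "the series" means these few. Any claim that something is new, unique, unknown or untested is made for them only; others in the source may bear on it.

In a functional assay on A549 cells (Homo sapiens) for antiproliferative activity, read by MTT assay, with a stated time of 72 h (a higher number here means a weaker inhibitor, a lower number a stronger inhibitor), compound 1 `COc1cc(C(=O)c2sc3ccccc3c2-c2ccc(Cl)cc2)cc(OC)c1OC` gives 7500 nM, while compound 2 `CCOc1ccc(Nc2c(C(=O)c3cc(OC)c(OC)c(OC)c3)sc3ccccc23)cc1` gives 1400 nM, the lower of the two numbers and so the stronger result. Compound 3 `CCOc1ccc(Nc2c(C(=O)c3cc(OC)c(OC)c(OC)c3)sc3cc(C)ccc23)cc1` keeps everything in compound 2 except for one small edit: methyl in place of hydrogen on an aromatic carbon. Going by the values given here, only one measured step is available as a guide, a 5.4-fold lower number from compound 1 to compound 2 (0.73 log units; beyond the scatter), and it is modest but beyond the scatter. That step swapped a different group, (4-ethoxyphenyl)amino in place of 4-chlorophenyl, so it says nothing direct about adding a methyl. Among the compounds with values here, with no measured methyl step to draw on, no change beyond the scatter is expected, and a shift in either direction remains possible. The expected change is a 1.2-fold lower number from compound 2 to compound 3 (0.07 log units; within the scatter). For compound 3, the estimated value is 1200 nM, within an expected range of 350 nM to 4000 nM.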

Compound 3, half-maximal inhibitory concentration: 5800 nM
For compound 3 the middle estimate is 4.8-fold (0.68 log units) below the measured one, outside the stated range (above it).
By their numbers in this assay, from the lowest: compound 2; then compounds 3 and 1 (each within the scatter of the next).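

Adding one methyl, a single carbon with no ring, to the six-membered aromatic ring of the fused system gives a 4.1-fold higher number from compound 2 to compound 3 (0.62 log units; beyond the scatter), so this position is sensitive to even a very small addition. The earlier step concerned a different site, the exchange of 4-chlorophenyl for (4-ethoxyphenyl)amino, and gave no sign of how this ring would respond to a new group. Nothing available explains why the methyl raises the number.

From the compounds shown here alone, it remains open whether this rise is specific to methyl or would follow any group at this carbon, a question that a fluorine atom, a methoxy group or a longer chain there could help settle. Going by these compounds, whether other carbons of the same ring respond in the same way also remains unknown.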